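The source may report more compounds than this note shows. Statements on the series, on what has been measured and on what is new or still open speak of the compounds shown alone.

Compound 1 `CN(C)CC[C@H](CSc1ccccc1)Nc1ccc(S(=O)(=O)NC(=O)c2ccc(N3CCN(Cc4ccccc4-c4ccc(Cl)cc4)CC3)cc2)cc1C(F)(F)F` gives in an assay on isolated protein for displacement of a labelled ligand from Bcl2-associated agonist of cell death (Homo sapiens), read by fluorescence polarization; on this read-out higher numbers stand for weaker inhibition and lower numbers for stronger inhibition < 1 nM, which is a limit of the assay.
Compound 2 `Cc1cc(S(=O)(=O)NC(=O)c2ccc(N3CCN(Cc4ccccc4-c4ccc(Cl)cc4)CC3)cc2)ccc1N[C@H](CCN(C)C)CSc1ccccc1` gives in this assay < 1 nM, likewise a limit.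
Compound 3 `CN(C)CC[C@H](CSc1ccccc1)Nc1ccc(S(=O)(=O)NC(=O)c2ccc(N3CCN(Cc4ccccc4-c4ccc(Cl)cc4)CC3)cc2)cc1S(=O)(=O)C(F)(F)F` gives in this assay < 1 nM, again a limit.

Compound 3 thus stands at the limit of < 1 nM in this assay, at which 3 of the 3 values shown sit. The change that leads to compound 4 `CN(C)CC[C@H](CSc1ccccc1)Nc1ccc(S(=O)(=O)NC(=O)c2ccc(N3CCN(Cc4ccccc4-c4ccc(Cl)cc4)CC3)cc2)cc1C#N` is cyano in place of (trifluoromethyl)sulfonyl on an aromatic carbon. The measured steps that touch this position, a step that the two limits leave unreadable from compound 1 to compound 3 and a step that the two limits leave unreadable from compound 2 to compound 3, are both hidden by the limits, and a step that the two limits leave unreadable from compound 1 to compound 2 is hidden as well, so no size or direction can be read from them. Compound 4 is therefore expected to remain where the three measured compounds sit, most likely again as a limit rather than a number. The expected step is a step that the limit leaves unreadable from compound 3 to compound 4. Compound 4 is estimated at 0.5 nM in this assay, with a range from 0.1 nM to 3 nM.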

Compound 4, inhibition constant: < 1 nM
Compound 4: only a limit was reported (the forecaster's own chance of this, stated with the estimate: 80%); the middle value lies beyond the limit too.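

The steps from compound 1, compound 2 and compound 3 to compound 4 cannot be read, since all four compounds sit at one limit: the limit of < 1 nM in this assay, at which 4 of the 4 values shown sit.

The compounds shown leave open whether the methyl, trifluoromethyl, (trifluoromethyl)sulfonyl and cyano compounds differ at all in this assay.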